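The source may report more compounds than this note shows. Statements on the series, on what has been measured and on what is new or still open speak of the compounds shown alone.

Compound 1 `CCCC(=O)N1CCC(c2cc(Cl)ccc2N)=N1` is one of two measured members of the series. In an assay on isolated protein for inhibition of Nitric oxide synthase, inducible (Homo sapiens), with a stated time of 30 min, tested at 1 mM (on this read-out lower numbers stand for less inhibition and higher numbers for more inhibition at the one concentration tested (going by the name of the read-out)), compound 1 gives 0.29%, the lowest of the two numbers recorded, and its nearest neighbour is compound 2 `CCCC(=O)N1CCC(c2ccccc2N)=N1`, which in this assay gives 0.35%. Within the data shown here, the only measured step, a number 0.1 percentage points higher from compound 1 to compound 2 (within the scatter), exchanges hydrogen for chloro on an aromatic carbon and leaves the read-out where it was. Both measured compounds show essentially no inhibition at the single concentration tested.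

Compound 3 `CCC(=O)N1CCC(c2cc(Cl)ccc2N)=N1` is not yet measured. It differs from compound 1 in one place: hydrogen in place of methyl on a saturated chain carbon, two bonds along the chain from a carbonyl carbon. Among the measured compounds shown here, no measured pair touches the propylcarbonyl group, so no step bears directly on this change; the one available step, a number 0.1 percentage points higher from compound 1 to compound 2 (within the scatter), shows only that a change elsewhere on the shared core left the read-out within the scatter. For the measured compounds named here, with both measured numbers near zero and no precedent for movement, the expected step is a number 0 percentage points higher from compound 1 to compound 3 (within the scatter), that is none beyond the scatter. Compound 3 is therefore estimated at 0.3% in this assay, with a range from -6% to 7%.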

Compound 3, a percentage reported as inhibition, at one concentration (the size of the read-out at that concentration, not a potency): 13.7%
Estimate against measurement, compound 3: 13.4 percentage points below; the measured number lies above the stated range.
By their numbers in this assay, from the lowest: compounds 1 and 2 (each within the scatter of the next); then compound 3.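

In this assay, the change from propylcarbonyl to propanoyl is the only one-place change shown that moves the read-out beyond the scatter, giving a number 13.4 percentage points higher from compound 1 to compound 3 (beyond the scatter). Set against a number 0.1 percentage points higher from compound 1 to compound 2 (within the scatter), where hydrogen replaces chloro on an aromatic carbon, this shows that the near-zero read-out of compound 1 is not fixed against every one-place change, and that removing a single methyl from the saturated chain is enough to shift it, although compound 3 at 13.7% still shows only modest inhibition at the one concentration tested. Nothing among the data shown accounts for this step.

Whether the read-out keeps moving along this chain remains open, since the compounds shown do not say how an acetyl group, a longer chain such as pentanoyl, or an amine in the same place would read. From the compounds shown here alone, it is also open whether hydrogen in place of chloro on an aromatic carbon would leave the read-out of compound 3 within the scatter, as it does for compound 1.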